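The compounds below may be only part of what the source reports. "The series", "measured", "known", "first", "only" and "open" are said of these compounds alone.

Three compounds have so far been measured in a functional assay on HEK293 cells for agonist activity at D(4) dopamine receptor (Homo sapiens), read by FLIPR; a higher number here means a larger maximal response, a lower number a smaller maximal response:

compound 1 `Cc1ccc([N+](=O)[O-])cc1NC(=O)CN1CCC(c2cccc[n+]2[O-])CC1` gives 76%
compound 2 `O=C(CN1CCC(c2cccc[n+]2[O-])CC1)Nc1ccc(F)cc1F` gives 74%
compound 3 `Oc1ccc(N2CCN(Cc3nc4ccccc4[nH]3)CC2)nc1` gives 70%

Compound 2 holds the second of the three numbers. Its nearest neighbour is compound 1, whose number is a little higher, and its furthest is compound 3, whose number is a little lower; both gaps lie within the usual scatter of this kind of measurement, so the three maximal responses cannot be told apart with any confidence. Among the measured compounds shown here, no pair among the measured compounds differs in a single place, so there is no directly comparable step to lean on.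

Compound 4 `O=C(CN1CCC(c2cccc[n+]2[O-])CC1)Nc1ccccc1F` has not been measured. It departs from compound 2 by hydrogen in place of fluoro on an aromatic carbon. For the measured compounds named here, with no measured step of this kind available, the expectation rests on compound 2 alone, with 74% as the anchor, and the step from compound 2 to compound 4 is expected to be no larger than the scatter in either direction, as no change at the digits printed from compound 2 to compound 4 (within the scatter) states. Compound 4 is therefore estimated at 74%, with a range from 62% to 86%.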

Compound 4, largest response reached (reported as efficacy), in percent of the reference or control that the assay uses: 63%
Compound 4: the middle estimate sits 11 percentage points above what was measured; the measured number falls inside the stated range.
By their numbers in this assay, from the lowest: compounds 4, 3, 2 and 1 (each within the scatter of the next, the first and the last beyond it).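

Replacing the fluoro group with hydrogen at this position, on the aromatic carbon para to a large group and meta to a fluoro group, gives a number 11 percentage points lower from compound 2 to compound 4 (beyond the scatter) in this assay. Among the compounds shown here, this is the first step between compounds that differ in one place, and it shows that the maximal response is sensitive to this one position: going from 2,4-difluorophenyl to 2-fluorophenyl is enough to change it, even with the rest of the structure held constant. Nothing available accounts for the size or direction of this step.

Going by these compounds, whether fluoro is specifically needed at this position remains open, as a chloro or methoxy group there could give a response close to that of either compound. The compounds shown also leave open what the remaining fluoro group contributes.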